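Replacing 2-fluorophenyl with 2,3-dihydroxyphenyl in compound 1

The source may hold more compounds than are shown below. What is called first, only, known or untested is meant among the compounds shown, and "the series" means these compounds.

For the measured compounds named here, two measured members define the series so far. Compound 1 `CCOC(=O)c1cnn(-c2nc(-c3ccccc3F)c(C#N)c(=O)n2C)c1N` gives 87 ug/mL in a functional assay, with a stated time of 150 min (a higher number here means a weaker inhibitor, a lower number a stronger inhibitor), and compound 2 `Cn1c(NN)nc(-c2ccccc2O)c(C#N)c1=O` gives 46 ug/mL in this assay. Compound 1 carries the highest of the two numbers, but the value of compound 2 lies within the scatter of it, so nothing separates the two on these data. Going by the values given here, no step between measured compounds that differ in one place is available.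

Compound 3 `CCOC(=O)c1cnn(-c2nc(-c3cccc(O)c3O)c(C#N)c(=O)n2C)c1N` is not yet measured. It differs from compound 1 as follows (2,3-dihydroxyphenyl in place of 2-fluorophenyl on an aromatic carbon). Among the compounds with values here, with no comparable step in hand, the size and direction of this change cannot be drawn from the data, and the expectation is a step no larger than the scatter, in either direction a 1.3-fold lower number from compound 1 to compound 3 (0.13 log units; within the scatter). On that basis compound 3 is estimated at 65 ug/mL in this assay, with a range from 25 ug/mL to 170 ug/mL.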

Compound 3, half-maximal inhibitory concentration: 58 ug/mL
Compound 3: the middle estimate sits 1.1-fold (0.05 log units) above what was measured; the measured number falls inside the stated range.
By their numbers in this assay, from the lowest: compounds 2, 3 and 1 (each within the scatter of the next).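

In this assay, placing 2,3-dihydroxyphenyl instead of 2-fluorophenyl on the aromatic carbon ortho to a cyano group gives a 1.5-fold lower number from compound 1 to compound 3 (0.18 log units; within the scatter), so the two groups are not separated at this position. For the compounds shown here, this is the first step that can be read at a single place: the entering group carries two hydrogen-bond donors and two hydrogen-bond acceptors, the leaving group carries neither, and the numbers still do not part beyond the scatter. Nothing on hand explains this outcome.

Still open, on these data alone, is whether a group of another kind at this position, such as an aminophenyl, a carboxyphenyl or a plain phenyl, would move the number beyond the scatter. A single hydroxyl, as in 3-hydroxyphenyl, on the core of compound 1 would also test whether both hydroxyl groups are tolerated independently.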